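Swapping an Imidazole for an Ethylpyrrolidine: Expected Solubility

The compounds below may be only part of what the source reports. "The series", "measured", "known", "first", "only" and "open" are said of these compounds alone.

Among the compounds with values here, compound 2, with the structure `Cc1cc(NCc2c[nH]cn2)n2nc(C)c(-c3ccccc3)c2n1`, holds the higher of the two solubility values measured so far. In a physicochemical assay for solubility, read by HPLC, using the shake flask method, measured as kinetic solubility, with a stated time of 2 h, at pH 7.4 (a lower number here means a less soluble compound, a higher number a more soluble compound), compound 2 gives 14600 nM. Its nearest neighbour is compound 1, `Cc1cc(NCc2cnccn2)n2nc(C)c(-c3ccccc3)c2n1`, which in this assay gives 7100 nM; the step of a 2.1-fold higher number from compound 1 to compound 2 (0.31 log units; beyond the scatter) separates them. Compound 3, `CCN1CCCC1CNc1cc(C)nc2c(-c3ccccc3)c(C)nn12`, is not yet measured. It differs from compound 2 by 1-ethylpyrrolidin-2-yl in place of 1H-imidazol-4-yl on a saturated chain carbon bound to a nitrogen on an aromatic ring. Within the data shown here, no measured step covers this change: the only step available, a 2.1-fold higher number from compound 1 to compound 2 (0.31 log units; beyond the scatter), exchanges one aromatic ring for another and does not involve the 1-ethylpyrrolidin-2-yl group. The expectation for compound 3 in this assay therefore rests on the value of compound 2 alone and carries a wide range. Compound 3 is expected to reach about 30000 nM, with a likely span from 8000 nM to 120000 nM. That estimate means an expected step of a 2.1-fold higher number from compound 2 to compound 3 (0.31 log units; beyond the scatter), a modest rise that may not stand beyond the usual scatter.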

Compound 3, solubility: 172000 nM
Beside the measured number, compound 3's estimate is 5.7-fold (0.76 log units) below it; the whole stated range lies below it.
By their numbers in this assay, from the lowest: compound 1; then compound 2; then compound 3.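

Within the data shown here, at this position, on a saturated chain carbon bound to a nitrogen on an aromatic ring, the earlier compounds showed only one aromatic ring exchanged for another. A non-aromatic ring now proves far more consequential in this assay: 1-ethylpyrrolidin-2-yl brings a 12-fold higher number from compound 2 to compound 3 (1.07 log units; beyond the scatter), and in place of pyrazin-2-yl it brings a 24-fold higher number from compound 1 to compound 3 (1.38 log units; beyond the scatter), while carrying no hydrogen-bond donor, so a high number here does not require the donor of 1H-imidazol-4-yl. No supporting measurement is available to explain this rise.

The change replaces the aromatic ring and adds an ethyl group in a single step, so the compounds shown cannot say which of the two matters. A pyrrolidin-2-yl group without the ethyl, or one carrying a propyl instead, would separate these two parts of the change.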